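Trifluoromethyl on the aryl ring of a cyclohexenol dienone

The source may report more compounds than this note shows. Statements on the series, on what has been measured and on what is new or still open speak of the compounds shown alone.

Within the data shown here, compound 2 `CC1=C(/C=C/C(=O)/C=C/c2ccccc2)C(C)(C)CCC1O` gives 12600 nM in a functional assay on PCa 2b cells (Homo sapiens) for cytotoxicity, read by MTT assay, with a stated time of 72 h (a higher number here means a weaker inhibitor, a lower number a stronger inhibitor), the highest of the three numbers so far. Compound 1 `CC1=CCCC(C)(C)C1/C=C/C(=O)/C=C/c1cc(C(F)(F)F)ccc1F` gives 3000 nM in this assay, and compound 3 `CC1=C(/C=C/C(=O)/C=C/c2ccccc2C(F)(F)F)C(C)(C)CCC1O` gives 2900 nM. Among the measured compounds shown here, the only one-place step, a 4.3-fold lower number from compound 2 to compound 3 (0.64 log units; beyond the scatter), came from trifluoromethyl in place of hydrogen on an aromatic carbon. Compound 4 `CC1=C(/C=C/C(=O)/C=C/c2cccc(C(F)(F)F)c2)C(C)(C)CCC1O` differs from compound 2 by trifluoromethyl in place of hydrogen on an aromatic carbon, the same kind of change on the same ring, so the step from compound 2 to compound 3 is the one that bears on it. A lower number in this assay is therefore expected for compound 4, of a size comparable to that step, a 2.8-fold lower number from compound 2 to compound 4 (0.45 log units; beyond the scatter). Compound 4 is estimated at 4500 nM in this assay, with a range from 2000 nM to 11000 nM.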

Compound 4, half-maximal inhibitory concentration: 2600 nM
The estimate for compound 4 lay 1.7-fold (0.24 log units) above the measured number; the measured number falls inside the stated range.
By their numbers in this assay, from the lowest: compounds 4, 3 and 1 (each within the scatter of the next); then compound 2.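

In this assay, trifluoromethyl on an aromatic carbon, meta to a large group, also lowers the number, with a 4.8-fold lower number from compound 2 to compound 4 (0.69 log units; beyond the scatter). The lower number is therefore not confined to the ring position of compound 3: compound 3 at 2900 nM and compound 4 at 2600 nM lie within the scatter of each other, so these two placements cannot be told apart. Nothing on hand explains the step. Going by these compounds, whether an amine or a carboxylic acid at this position would also give a lower number remains open. So does the effect of trifluoromethyl without the accompanying fluorine on the core of compound 1.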